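Indazolyl Replacement on the Shared Core of Compound 1

The source may report more compounds than this note shows. Statements on the series, on what has been measured and on what is new or still open speak of the compounds shown alone.

Compound 1 `COc1cc(-c2ccnc3cc(-c4ccc(C)cc4)nn23)cc(OC)c1OC` carries a 4-methylphenyl group on its shared core. In a functional assay on A549 cells (Homo sapiens) for inhibition, read by CCK-8 assay, with a stated time of 48 h (on this read-out higher numbers stand for weaker inhibition and lower numbers for stronger inhibition), compound 1 gives 3 nM, the lowest number among the three measured compounds. Compound 2 `COc1cc(-c2ccnc3cc(-c4ccc5c(ccn5C)c4)nn23)cc(OC)c1OC` gives 15 nM, and compound 3 `COc1cc(-c2ccnc3cc(-c4ccc5ccn(C)c5c4)nn23)cc(OC)c1OC` gives 829 nM. The measured steps show that the ring attached at this position matters greatly: a 5.0-fold higher number from compound 1 to compound 2 (0.70 log units; beyond the scatter), whereas a 280-fold higher number from compound 1 to compound 3 (2.44 log units; beyond the scatter), and a 55-fold higher number from compound 2 to compound 3 (1.74 log units; beyond the scatter).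

Compound 4 `COc1cc(-c2ccnc3cc(-c4ccc5cnn(C)c5c4)nn23)cc(OC)c1OC` is not yet measured. Its difference from compound 1 is 1-methyl-1H-indazol-6-yl in place of 4-methylphenyl on an aromatic carbon. The entering group is a fused two-ring system joined through its six-membered ring at the same point of attachment as the 1-methyl-1H-indol-6-yl of compound 3, so the step from compound 1 to compound 3 is the one that bears most directly on it, while the step from compound 1 to compound 2 shows that a fused ring as such can still be tolerated.

Because a 280-fold higher number from compound 1 to compound 3 (2.44 log units; beyond the scatter) is the closest measured precedent, a large weakening is expected for compound 4, so that a 200-fold higher number from compound 1 to compound 4 (2.30 log units; beyond the scatter). Compound 4 is therefore estimated at 600 nM, with a range of 120 nM to 3000 nM.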

Compound 4, half-maximal inhibitory concentration: 233 nM
The estimate for compound 4 lay 2.6-fold (0.41 log units) above the measured number; the measured number falls inside the stated range.
By their numbers in this assay, from the lowest: compound 1; then compound 2; then compound 4; then compound 3.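

In this assay the 1-methyl-1H-indazol-6-yl group shows a 78-fold higher number from compound 1 to compound 4 (1.89 log units; beyond the scatter) and so joins the 1-methyl-1H-indol-6-yl group of compound 3 well short of the 4-methylphenyl group of compound 1. These two fused groups are nevertheless not interchangeable, since a change confined to the five-membered ring gives a 3.6-fold lower number from compound 3 to compound 4 (0.55 log units; beyond the scatter) and thus shows that this ring has a measurable bearing on the read-out, although the change recovers only a small part of what was lost from compound 1. The 1-methyl-1H-indol-5-yl group remains the closest of the fused groups to compound 1, as the comparison with the new compound gives a 16-fold higher number from compound 2 to compound 4 (1.19 log units; beyond the scatter) and leaves compound 2 clearly ahead.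

No evidence accompanying these numbers accounts for the differences among the fused groups. Still open, on these data alone, is whether a 1-methyl-1H-indazol-5-yl group would stand near compound 2, and whether an amine, a carboxylic acid or a longer chain in place of the methyl of the 4-methylphenyl group would keep the number of compound 1.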